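A few compounds are considered here, and "the series" means these few. Any claim that something is new, unique, unknown or untested is made for them only; others in the source may bear on it.

Of the compounds shown here, three have so far been measured in a functional assay on HEK293 cells for agonist activity at Bombesin receptor subtype-3 (Mus musculus), read by luminescence and calcium flux, with a stated time of 10 min; a lower number here means that less compound is needed, a higher number that more compound is needed for the effect. Compound 1 `CCC(C)(C)Cc1c[nH]c(CCc2ccc(-c3cccc(C)n3)cc2)n1` gives 106 nM. Compound 2 `CCC(C)(C)Cc1c[nH]c(CCc2ccc(-c3cccc(C#N)n3)cc2)n1` gives 115 nM, and the change between them, cyano in place of methyl on an aromatic carbon, produced a 1.1-fold higher number from compound 1 to compound 2 (0.04 log units; within the scatter). Compound 3 `CCC(C)(C)Cc1c[nH]c(CCc2ccc(-c3ccc(F)cn3)cc2)n1` gives 105 nM. The steps leading to it both lie within the scatter: a 1.0-fold lower number from compound 1 to compound 3 (0.00 log units; within the scatter) and a 1.1-fold lower number from compound 2 to compound 3 (0.04 log units; within the scatter). On these numbers compound 3 cannot be told apart from compound 1 or compound 2.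

Compound 4 `CCC(C)(C)Cc1c[nH]c(CCc2ccc(-c3csnn3)cc2)n1` has not yet been measured in this assay. It differs from compound 3 in one place: 1,2,3-thiadiazol-4-yl in place of 5-fluoropyridin-2-yl on an aromatic carbon. For the measured compounds named here, the steps that bear on this change are the two exchanges of the ring at that same aromatic carbon, from compound 1 to compound 3 and from compound 2 to compound 3, both within the scatter, together with the step from compound 1 to compound 2 that alters a group on that ring, also within the scatter. Going by the values given here, nothing measured so far separates one ring at this position from another, though the ring entering in compound 4 is of a kind not yet tried. The step from compound 3 to compound 4 is therefore expected to be small, a 1.2-fold higher number from compound 3 to compound 4 (0.09 log units; within the scatter), but with a wider margin than the measured steps. Compound 4 is estimated to give 130 nM in this assay, within a range from 50 nM to 350 nM.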

Compound 4, half-maximal effective concentration: 109 nM
Beside the measured number, compound 4's estimate is 1.2-fold (0.08 log units) above it, within the range that was stated.
By their numbers in this assay, from the lowest: compounds 3, 1, 4 and 2 (each within the scatter of the next).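

In this assay, compound 4 brings a five-membered aromatic ring with three hetero atoms, 1,2,3-thiadiazol-4-yl, to the aromatic carbon para to a large group, where compounds 1, 2 and 3 each carry a six-membered aromatic ring with one hetero atom. This exchange of ring size and hetero atoms does not separate compound 4 from any of the three pyridine compounds (a 1.0-fold higher number from compound 3 to compound 4 (0.02 log units; within the scatter); a 1.0-fold higher number from compound 1 to compound 4 (0.01 log units; within the scatter); a 1.1-fold lower number from compound 2 to compound 4 (0.02 log units; within the scatter)), so the earlier finding that the pyridine rings cannot be told apart now extends, across these four compounds, to a ring of a different kind. No measurement at hand accounts for this result.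

Going by these compounds, all four compounds keep an aromatic ring at this place, so it remains open whether a saturated ring such as piperidine, or an open group such as an amine, a carboxylic acid or a longer alkyl chain, would also leave the number unchanged. On these data alone, it is also open whether these rings would stay interchangeable if the shared core were altered, for example with a phenyl ring in place of the imidazole-bound alkyl chain.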